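This account rests on a few compounds, and the source may have more. Where it says the series, first, only, none or still open, it means among the compounds named here.

Measured so far:

Compound 1, `Cn1c(-c2cccc3ccccc23)nnc1[S+](C)[O-]`, in a functional assay on the whole organism for antagonist activity, with Mus musculus as the target (a lower number here means that less compound is needed, a higher number that more compound is needed for the effect), gives a limit of > 200 mg/kg.

Compound 2, `Cn1c(-c2cccc3ccccc23)nnc1S(C)(=O)=O`, in this assay gives a limit of > 200 mg/kg.

Compound 3, `Cn1nc([S+](C)[O-])nc1-c1ccccc1`, in this assay gives a limit of > 200 mg/kg.

None of these three values is a number; each is a limit of the assay, the point beyond which it does not report. Compound 1 and compound 2 share a core and differ in one place: a group of 4 heavy atoms (1 carbon, 2 oxygen, 1 sulfur; no ring) in place of a group of 3 heavy atoms (1 carbon, 1 oxygen, 1 sulfur; no ring), on an aromatic carbon. The step that the two limits leave unreadable from compound 1 to compound 2 therefore has no readable size. Compound 3 carries a different core; the difference between the two cores is not broken down here.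

Compound 4, `Cn1nc(S(C)(=O)=O)nc1-c1ccccc1`, has not yet been measured in this assay. It differs from compound 3 by the same kind of change that turns compound 1 into compound 2: a group of 4 heavy atoms (1 carbon, 2 oxygen, 1 sulfur; no ring) in place of a group of 3 heavy atoms (1 carbon, 1 oxygen, 1 sulfur; no ring), on an aromatic carbon. The surroundings of the place are not identical. In compound 1 the group sits next to the ring atom that bears a methyl group and two ring bonds from the ring atom that bears a large group, whereas in compound 3 it sits two ring bonds from the ring atom that bears a methyl group.

The expectation for compound 4 rests on (the limit of > 200 mg/kg in this assay, at which 3 of the 3 values shown sit). Compound 4 is expected to give about 300 mg/kg, with a range from 120 mg/kg to 1000 mg/kg, and most likely only a limit again. Among the measured compounds shown here, the expected step is a step that the limit leaves unreadable from compound 3 to compound 4, which is set near zero because every value so far sits at the limit of > 200 mg/kg in this assay, at which 3 of the 3 values shown sit.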

Compound 4, dose for half-maximal effect: > 200 mg/kg
Compound 4 gave a limit, no number; the forecaster's own chance of this, stated with the estimate: 85%; the middle value does not contradict the limit.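

In this assay compound 4 gives > 200 mg/kg, which is a limit of the assay and not a number. Compound 3 also gives only a limit, so the step between compound 3 and compound 4 cannot be read. The compounds shown leave open what dose, if any, gives a readable value in this assay, and what methylsulfonyl does to that dose: the limit of > 200 mg/kg in this assay, at which 4 of the 4 values shown sit.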